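Methyl Branching of the Acid Chain and Lipophilicity

This account rests on a few compounds, and the source may have more. Where it says the series, first, only, none or still open, it means among the compounds named here.

Measured compounds:
Compound 1 `C[C@@H](C(=O)O)c1nn(Cc2cn3cc(OCC4CC4)c(Cl)cc3n2)c2ccccc2c1=O` gives 2.41 in a physicochemical assay for lipophilicity, at pH 7.4; on this read-out lower numbers stand for lower lipophilicity and higher numbers for higher lipophilicity.
Compound 2 `O=C(O)Cn1nc(Cn2cc3cc(OCC4CC4)c(Cl)cc3n2)c2ccccc2c1=O` gives 2.79 in this assay.
Compound 3 `O=C(O)Cc1nn(Cc2cn3cc(OCC4CC4)c(Cl)cc3n2)c2ccccc2c1=O` gives 2.13 in this assay.

Compound 2 and compound 3 are built from the same atoms joined differently; the difference between the two cores is not broken down here. Compound 2 stands highest of the three, beyond the scatter from both others. From compound 3 to compound 1 the change is methyl in place of hydrogen on a saturated chain carbon bound to an aromatic carbon and a carbonyl carbon, and it gives a number 0.28 log units higher from compound 3 to compound 1 (within the scatter).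

Compound 4 `C[C@H](C(=O)O)n1nc(Cn2cc3cc(OCC4CC4)c(Cl)cc3n2)c2ccccc2c1=O` is not yet measured. It arises from compound 2 by methyl in place of hydrogen on a saturated chain carbon bound to an aromatic nitrogen and a carbonyl carbon, the same kind of change, though here the chain carbon is bound to an aromatic nitrogen rather than an aromatic carbon. A step of a number 0.26 log units higher from compound 2 to compound 4 (within the scatter) is expected for compound 4, resting on the step of a number 0.28 log units higher from compound 3 to compound 1 (within the scatter). Compound 4 is therefore estimated at 3.05, between 2.75 and 3.35.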

Compound 4, distribution coefficient: 2.99
Estimate against measurement, compound 4: 0.06 log units above; the range from low to high includes it.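

In this assay, the change from carboxymethyl to 1-carboxyethyl gives a number 0.20 log units higher from compound 2 to compound 4 (within the scatter), and the same kind of change on the other core gives a number 0.28 log units higher from compound 3 to compound 1 (within the scatter). The change therefore carries from one core to the other without a step beyond the scatter on either, but neither step on its own establishes a real difference, and two pairs cannot show how it would behave on a further core. Nothing available explains the size of either step.

The compounds shown leave open how an ethyl group on the same chain carbon would read in this assay. They also leave open what an amide in place of the carboxylic acid would give on either core.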